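The source may hold more compounds than are shown below. What is called first, only, known or untested is meant among the compounds shown, and "the series" means these compounds.

Values in an ADME assay on Vero cells (Chlorocebus sabaeus) for cytotoxicity, read by reporter gene assay, with a stated time of 4 days (a higher number here means a weaker inhibitor, a lower number a stronger inhibitor), for the series so far:
- compound 1 `CCCC(C)C(=O)NCC(C)(C)CC1=C(O)C(=O)c2ccccc2C1=O` 48100 nM
- compound 2 `CCCCCCC(C)C(=O)NCC(C)(C)CC1=C(O)C(=O)c2ccccc2C1=O` 15500 nM
- compound 3 `CCCCCCCCCCC(=O)NCC(C)(C)CC1=C(O)C(=O)c2ccccc2C1=O` 14900 nM

Compound 3 stands level with compound 2 (a 1.0-fold lower number from compound 2 to compound 3 (0.02 log units; within the scatter)). Both lie clear of compound 1 (steps: a 3.1-fold lower number from compound 1 to compound 2 (0.49 log units; beyond the scatter) and a 3.2-fold lower number from compound 1 to compound 3 (0.51 log units; beyond the scatter)).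

Next in the series is compound 4 `CCCCCCCCCCCCCCCCCC(=O)NCC(C)(C)CC1=C(O)C(=O)c2ccccc2C1=O`, which extends the decyl chain of compound 3 (change: heptyl in place of hydrogen on a saturated chain carbon, ten or more bonds along the chain from a carbonyl carbon).

Among the measured compounds shown here, three measured steps bear on this change, all of them changes in the chain on the carbonyl carbon. The two steps away from compound 1 are modest, while the step between compound 2 and compound 3 shows no change despite the different chains. For the measured compounds named here, with only three compounds, the trend is thin, and no chain of this length has been measured. The closest guide is the flat step (compound 3 against compound 2: a 1.0-fold lower number from compound 2 to compound 3 (0.02 log units; within the scatter)), so no step beyond the scatter is expected in this assay for compound 4.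

The expected step is small (estimated: a 1.2-fold lower number from compound 3 to compound 4 (0.09 log units; within the scatter)). Compound 4 is estimated at 12000 nM (expected range 5000 nM to 30000 nM).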

Compound 4, half-maximal inhibitory concentration: 5760 nM
For compound 4 the middle estimate is 2.1-fold (0.32 log units) above the measured one; low and high end bracket the measured number.
By their numbers in this assay, from the lowest: compound 4; then compounds 3 and 2 (each within the scatter of the next); then compound 1.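

In this assay heptyl in place of hydrogen on a saturated chain carbon, ten or more bonds along the chain from a carbonyl carbon, gives a 2.6-fold lower number from compound 3 to compound 4 (0.41 log units; beyond the scatter) and so moves the number beyond the scatter. The earlier step of a 1.0-fold lower number from compound 2 to compound 3 (0.02 log units; within the scatter) lay within the scatter, so the result shows that the far end of the chain can still alter the number when the chain is extended from decyl. No measurement in hand explains this step.

As far as these compounds go, whether a chain longer than that of compound 4 continues this trend remains open. Also open, from the compounds shown here alone, is how a carboxylic acid or an amine at the end of the chain would compare with the plain heptyl extension in this assay.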